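Replacing the Basic Side Chain With Cyclopropyl

The compounds below may be only part of what the source reports. "The series", "measured", "known", "first", "only" and "open" are said of these compounds alone.

Measured so far:
- compound 1, `COc1ncc(-c2ccc3nc(NC(=O)NCCN4CCCC4)sc3c2)cc1NS(=O)(=O)c1ccc(F)cc1`: 300 nM
- compound 2, `COc1ncc(-c2ccc3nc(NC(=O)NCCN(C)C)sc3c2)cc1NS(=O)(=O)c1ccc(F)cc1`: 470 nM

Both compounds were tested in a functional assay on A549 cells (Homo sapiens) for antiproliferative activity, read by MTT assay, with a stated time of 72 h; on this read-out higher numbers stand for weaker inhibition and lower numbers for stronger inhibition. Compound 1 holds the lowest of the two numbers, and its nearest neighbour is compound 2, separated by a 1.6-fold higher number from compound 1 to compound 2 (0.19 log units; within the scatter), a step that lies within the scatter and therefore says nothing about order between the two.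

Compound 3, `COc1ncc(-c2ccc3nc(NC(=O)NC4CC4)sc3c2)cc1NS(=O)(=O)c1ccc(F)cc1`, has not been measured. It differs from compound 1 in one place: cyclopropyl in place of 2-(pyrrolidin-1-yl)ethyl on an amide-type nitrogen. For the measured compounds named here, the only measured step, from compound 1 to compound 2, swaps one amine substituent for another at the far end of the chain and leaves the chain itself in place; it does not touch the question of what happens when the whole 2-(pyrrolidin-1-yl)ethyl group gives way to cyclopropyl. The data thus offer no direct guide, and any expectation rests on the step being small and on the change being larger than the one already seen. For compound 3 a somewhat higher number is expected, estimated at 650 nM, within 150 nM to 2800 nM, which corresponds to an expected step of a 2.2-fold higher number from compound 1 to compound 3 (0.34 log units; beyond the scatter).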

Compound 3, half-maximal inhibitory concentration: 900 nM
Beside the measured number, compound 3's estimate is 1.4-fold (0.14 log units) below it; low and high end bracket the measured number.
By their numbers in this assay, from the lowest: compounds 1, 2 and 3 (each within the scatter of the next, the first and the last beyond it).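

In this assay the whole 2-(pyrrolidin-1-yl)ethyl group on the amide-type nitrogen gives way to cyclopropyl with a 3.0-fold higher number from compound 1 to compound 3 (0.48 log units; beyond the scatter) as the result, a modest step beyond the scatter, whereas the earlier change at the far end of the chain could not be read as any order. Set against the 2-(dimethylamino)ethyl group, the same replacement gives a 1.9-fold higher number from compound 2 to compound 3 (0.28 log units; within the scatter) and so stays within the scatter, which means the step beyond it depends on which of the two chains leaves. Cyclopropyl carries no nitrogen, yet compound 3 still gives 900 nM in this read-out, so the amine of the side chain is not needed for a measurable number on these cells.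

The compounds shown do not tell whether a morpholine or a piperidine at the end of the ethyl chain, or a longer propyl chain carrying the pyrrolidine, would hold or shift the number. Nor do they tell whether a plain ethyl or a cyclobutyl on the same nitrogen would read like cyclopropyl, and no measurement at hand explains the step itself.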